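Adding ethyl to the chain of compound 2

This account rests on a few compounds, and the source may have more. Where it says the series, first, only, none or still open, it means among the compounds named here.

In a functional assay, with stated times of 30 s and 6 min, in the presence of a further agent that is not named here (a higher number here means a weaker inhibitor, a lower number a stronger inhibitor), compound 1 (`CCCCCCCCCCOc1cc(OC)ccc1C(C)=O`) gives 26600000 nM and compound 2 (`CCCCCCCCCCCCOc1cc(OC)ccc1C(C)=O`) gives 28500000 nM. For the measured compounds named here, these are the only two measurements so far. They lie within the usual scatter of repeated measurements of each other, so compound 2 stands level with compound 1 on the numbers available.

Compound 3 (`CCCCCCCCCCCCCCOc1cc(OC)ccc1C(C)=O`) has not yet been measured. It differs from compound 2 by one structural change: ethyl in place of hydrogen on a saturated chain carbon, ten or more bonds along the chain from an oxygen on an aromatic ring.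

Going by the values given here, the same change has been measured exactly once, and that single step gives the only guide: a 1.1-fold higher number from compound 1 to compound 2 (0.03 log units; within the scatter). It stayed within the scatter. One step is thin evidence, and nothing yet shows how a still longer chain behaves, so the range must stay wide. In this assay, no step beyond the scatter is expected. The estimated step is a 1.0-fold higher number from compound 2 to compound 3 (0.01 log units; within the scatter). For compound 3 the expected value is 29000000 nM, with an estimated range from 14000000 nM to 60000000 nM.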

Compound 3, half-maximal inhibitory concentration: 35900000 nM
Compound 3: middle estimate off by 1.2-fold (0.09 log units), on the low side, and the stated range covers the measured number.
By their numbers in this assay, from the lowest: compounds 1, 2 and 3 (each within the scatter of the next).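

In this assay, ethyl in place of hydrogen on a saturated chain carbon, ten or more bonds along the chain from an oxygen on an aromatic ring, now gives a 1.3-fold higher number from compound 2 to compound 3 (0.10 log units; within the scatter) and so stays within the scatter for a second time, which means the earlier step no longer stands alone. Read as one larger change, butyl in place of hydrogen at that same place gives a 1.3-fold higher number from compound 1 to compound 3 (0.13 log units; within the scatter) and also stays within the scatter, so even the two most distant chains shown here cannot be told apart in this assay. No supporting measurement is available to explain why these chains read alike.

Going by these compounds, all three compounds share one core and differ only in the chain on that oxygen, so it remains open how a much shorter chain, such as butyl, or a chain longer than any of these would read. On these data alone, it is also open whether an amine or a carboxylic acid placed at the far end of the chain would produce a step beyond the scatter.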